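The source may hold more compounds than are shown below. What is called first, only, known or untested is meant among the compounds shown, and "the series" means these compounds.

Measured so far:
compound 1, `CCCCCCCCCCCCCCCCCCNC(=O)[C@@H]1CSC(c2cccc(O)c2)N1`: 1700 nM in a functional assay on LNCaP cells (Homo sapiens) for antiproliferative activity, read by sulforhodamine B assay; on this read-out lower numbers stand for stronger inhibition and higher numbers for weaker inhibition
compound 2, `CCCCCCCCCCCCCCCCCCNC(=O)[C@@H]1CSC(c2ccc(N(C)C)cc2)N1`: 1600 nM in this assay

Compound 1 and compound 2 share a core and differ only in the aromatic group on a saturated ring carbon, and their two numbers in this assay sit within the usual scatter of each other, as the step of a 1.1-fold lower number from compound 1 to compound 2 (0.03 log units; within the scatter) shows. On the numbers shown, compound 2 therefore stands beside compound 1 rather than apart from it.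

Compound 3, `CCCCCCCCCCCCCCCCCCNC(=O)[C@@H]1CSC(c2c(OC)cc(OC)cc2OC)N1`, is not yet measured. It differs from compound 2 in one place: 2,4,6-trimethoxyphenyl in place of 4-(dimethylamino)phenyl on a saturated ring carbon

Within the data shown here, the only measured step that bears on this change is the one at the same position, a 1.1-fold lower number from compound 1 to compound 2 (0.03 log units; within the scatter), which swapped one aromatic group for another without moving the number beyond the scatter. That is one step only, but it gives no sign that the aromatic group at this position shifts the number. For compound 3 the expected step in this assay is no change at the digits printed from compound 2 to compound 3 (within the scatter), with no movement beyond the scatter foreseen. Compound 3 is estimated at 1600 nM, within a range of 700 nM to 3600 nM.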

Compound 3, half-maximal inhibitory concentration: 2400 nM
Beside the measured number, compound 3's estimate is 1.5-fold (0.18 log units) below it; low and high end bracket the measured number.
By their numbers in this assay, from the lowest: compounds 2, 1 and 3 (each within the scatter of the next).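

Set beside compound 1 and compound 2, compound 3 adds a third aromatic group at this saturated ring carbon, and a 1.5-fold higher number from compound 2 to compound 3 (0.18 log units; within the scatter) in this assay shows that a group with more heavy atoms and more hydrogen-bond acceptors still leaves the number within the scatter. The comparison with the hydroxyl-bearing compound agrees, with a 1.4-fold higher number from compound 1 to compound 3 (0.15 log units; within the scatter), so all three aromatic groups shown at this position give numbers that cannot be told apart, and none of the three compounds goes against this. No measurement shown here offers an explanation for how close these numbers lie.

The compounds shown leave open whether a group of another kind at this ring carbon, such as a phenyl ring bearing a carboxylic acid or a non-aromatic cyclohexyl group, would move the number beyond the scatter. They also leave open how much the octadecyl chain on the amide contributes to the number, a question that a compound with a shorter chain in its place could address.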